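Ortho substituent swap on the benzoic acid amide

A few compounds are considered here, and "the series" means these few. Any claim that something is new, unique, unknown or untested is made for them only; others in the source may bear on it.

Measured so far:
compound 1 `COc1ccc(-c2nc3cc(F)c(F)cc3n2[C@H](C(=O)N[C@H]2CC[C@H](C(=O)O)CC2)C2CCCCC2)c(Cl)n1`: 1100 nM
compound 2 `O=C(O)c1cccc(NC(=O)C(C2CCCCC2)n2c(-c3ccc(Cl)cc3)nc3cc(F)c(F)cc32)c1`: 10700 nM
compound 3 `O=C(O)c1ccc(NC(=O)[C@H](C2CCCCC2)n2c(-c3ccc(Cl)cc3)nc3cc(F)c(F)cc32)c(C(F)(F)F)c1`: 50 nM

In a functional assay for agonist activity at Bile acid receptor (Homo sapiens), read by a luciferase reporter (a lower number here means that less compound is needed, a higher number that more compound is needed for the effect), compound 3 gives the lowest number of the three and is the most potent compound here; compound 1 sits a good way above it and compound 2 further still, both gaps beyond the scatter. No pair among these three differs in only one place, so no single-point step is available to lean on.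

Compound 4 `COc1cc(C(=O)O)ccc1NC(=O)[C@H](C1CCCCC1)n1c(-c2ccc(Cl)cc2)nc2cc(F)c(F)cc21` differs from compound 3 by methoxy in place of trifluoromethyl on an aromatic carbon. Nothing in the measured set shows what a change at this position does; the nearest comparison, compound 2, lacks any group there and carries the carboxy group elsewhere, so it is not a clean guide. For compound 4 the expectation is a moderate move towards a higher number in this assay, a 3.0-fold higher number from compound 3 to compound 4 (0.48 log units; beyond the scatter), with wide uncertainty in both directions. Compound 4 is estimated at 150 nM, within a range of 40 nM to 800 nM.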

Compound 4, half-maximal effective concentration: 10400 nM
Compound 4: the middle estimate sits 69-fold (1.84 log units) below what was measured; the measured number lies above the stated range.
By their numbers in this assay, from the lowest: compound 3; then compound 1; then compounds 4 and 2 (each within the scatter of the next).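

In this assay, going by these compounds alone, the place ortho to a large group and meta to a carboxy group turns out to be highly sensitive: methoxy in place of trifluoromethyl on an aromatic carbon gives a 210-fold higher number from compound 3 to compound 4 (2.32 log units; beyond the scatter) as the first single-point step, and a large one. The low number of compound 3 therefore does not come from the rest of the molecule alone, and methoxy cannot stand in for trifluoromethyl at this place. Nothing available explains why these two groups differ so sharply.

As far as these compounds go, it remains open whether the loss is particular to methoxy or whether most groups other than trifluoromethyl would behave the same way here; a methyl group, a nitrile or an ethoxy group would help separate these readings. Also open, from the compounds shown here alone, is whether a step of this size would recur with a different group in place of the chlorophenyl on the shared core.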